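This account rests on a few compounds, and the source may have more. Where it says the series, first, only, none or still open, it means among the compounds named here.

Compound 1 `COc1ccc(Cc2cc(OC3CCCCC3C)c(C(C)C)c(=O)[nH]2)cc1`: 74500 nM
Compound 2 `CC1CCCCC1Oc1cc(CCc2ccccc2)[nH]c(=O)c1I`: > 300000 nM, a limit of the assay and not a number

Among the measured compounds shown here, in an ADME assay on MT4 cells (Homo sapiens) for cytotoxicity, read by XTT assay, with a stated time of 3 days (on this read-out lower numbers stand for higher toxicity in this test and higher numbers for lower toxicity in this test), compound 1 gives 74500 nM, the only actual number so far. For compound 2 the assay reports only a limit, > 300000 nM. Compound 1 is therefore the single fixed point on this scale.

Compound 3 `Cc1ccc(Cc2cc(OC3CCCCC3C)c(C(C)C)c(=O)[nH]2)cc1` keeps the core of compound 1 and changes one group: methyl in place of methoxy on an aromatic carbon. Put simply, this is methyl in place of methoxy on an aromatic carbon, turning 4-methoxybenzyl into 4-methylbenzyl. For the measured compounds named here, no measured pair here shows what such a swap does to the read-out, so the data point in neither direction. The expectation rests on compound 1 at 74500 nM, and no change beyond the usual scatter is foreseen in this assay. The expected 1.1-fold lower number from compound 1 to compound 3 (0.03 log units; within the scatter) is small and has no firm direction. For compound 3 the estimated value is 70000 nM, with an expected range from 30000 nM to 170000 nM.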

Compound 3, half-maximal cytotoxic concentration: 112000 nM
Compound 3: middle estimate off by 1.6-fold (0.20 log units), on the low side; measured number inside the range.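

Among the compounds shown here, the first step between two real numbers can now be read: in this assay, replacing methoxy with methyl on the aromatic carbon para to a large group gives a 1.5-fold higher number from compound 1 to compound 3 (0.18 log units; within the scatter). That step lies within the scatter of repeated measurements, so turning 4-methoxybenzyl into 4-methylbenzyl, which removes an oxygen and the one hydrogen-bond acceptor counted for methoxy, shows no detectable effect on this read-out. Compound 2 remains a limit and not a number, and it differs from the other two compounds in more than one place, so no step to it can be read: the limit of > 300000 nM in this assay, at which 1 of the 3 values shown sits.

On these data alone, a single pair says little about this position as a whole, and it remains open whether an amine, a carboxylic acid or a longer chain on the same aromatic carbon would shift the number beyond the scatter. As far as these compounds go, it is equally open whether the swap from methoxy to methyl would read the same with different groups elsewhere on the shared core.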